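Trifluoromethyl in place of fluoro: compound 2 to compound 3

The source may hold more compounds than are shown below. What is called first, only, known or untested is meant among the compounds shown, and "the series" means these compounds.

In a functional assay on MCF-10A cells (Homo sapiens) for antiproliferative activity, with a stated time of 48 h (on this read-out lower numbers stand for an effect already at smaller amounts and higher numbers for an effect only at larger amounts of compound), compound 2 `COc1ccc2nc(C)cc(NCc3ccc(F)cc3F)c2c1` gives 15000 nM, level with compound 1 `COc1ccc2nc(C)cc(NCc3ccccc3F)c2c1` at 17000 nM. Going by the values given here, these are the only two numbers so far, and they cannot be ranked. Among the compounds with values here, the single measured step is a 1.1-fold lower number from compound 1 to compound 2 (0.05 log units; within the scatter), and it is fluoro in place of hydrogen on an aromatic carbon.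

Compound 3 `COc1ccc2nc(C)cc(NCc3ccc(F)cc3C(F)(F)F)c2c1` carries trifluoromethyl in place of fluoro on an aromatic carbon, ortho to a large group and meta to a fluoro group: trifluoromethyl in place of fluoro on an aromatic carbon. Within the data shown here, no measured step exchanges these two groups, so the series holds no direct precedent, and the one step available is only a loose guide. Among the measured compounds shown here, it is also the only evidence on how this part of the structure responds. On that basis, no step beyond the scatter is expected in this assay, and no direction is favoured with any confidence. The expected change is a 1.2-fold lower number from compound 2 to compound 3 (0.06 log units; within the scatter), which is an estimate resting on one small step. For compound 3 the estimated value is 13000 nM, with an expected range of 6000 nM to 28000 nM.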

Compound 3, half-maximal effective concentration: 4200 nM
For compound 3 the middle estimate is 3.1-fold (0.49 log units) above the measured one, outside the stated range (below it).
By their numbers in this assay, from the lowest: compound 3; then compounds 2 and 1 (each within the scatter of the next).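

In this assay, going by these compounds alone, the aromatic carbon ortho to a large group and meta to a fluoro group is the first place to respond: the exchange of fluoro for trifluoromethyl gives a 3.6-fold lower number from compound 2 to compound 3 (0.55 log units; beyond the scatter) and so lies beyond the scatter. Within the data shown here, the only earlier step, a 1.1-fold lower number from compound 1 to compound 2 (0.05 log units; within the scatter), stayed within the scatter and concerned a fluoro in place of hydrogen, so it gave no sign that a change on this ring could move the number at all. The exchange replaces 1 heavy atom with 4 and adds no hydrogen-bond donor or acceptor, but no measurement here explains the step.

From the compounds shown here alone, whether the step belongs to trifluoromethyl itself or would also appear with a chlorine, a methyl or a methoxy group on the same carbon stays open, as does the outcome with an amine or a carboxylic acid there. Also open is whether the step depends on the fluoro group meta to this carbon, since the one trifluoromethyl compound shown, compound 3, carries both groups.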